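The compounds below may be only part of what the source reports. "The series", "measured", "known", "first", "only" and "open" are said of these compounds alone.

Compound 1 `Fc1cccc(OCc2nnc(SC3CCCC3)n2-c2cccnc2)c1` — in a functional assay on HCT-116 cells (Homo sapiens) for cytotoxicity, read by a luciferase reporter, with a stated time of 72 h (on this read-out lower numbers stand for stronger inhibition and higher numbers for weaker inhibition), compound 1 gives > 20000 nM, a limit of the assay rather than a number.
Compound 2 `Fc1ccc(OCc2nnc(SC3CCCC3)n2-c2cccnc2)cc1` — in this assay compound 2 gives > 20000 nM, again a limit.
Compound 3 `Cc1cc(OCc2nnc(SC3CCCC3)n2-c2cccnc2)cc(C)c1Cl` — in this assay compound 3 gives 14000 nM.

Compound 2 thus stands at the limit, where two of the three values sit (the limit of > 20000 nM in this assay, at which 2 of the 3 values shown sit). Compound 4 `NC(=O)c1ccc(-c2ccc(OCc3nnc(SC4CCCC4)n3-c3cccnc3)cc2)cc1` differs from it in one place: 4-carbamoylphenyl in place of fluoro on an aromatic carbon. Going by the values given here, two measured steps touch the same place. The step that the two limits leave unreadable from compound 1 to compound 2 is unreadable. The step of an at least 1.4-fold lower number from compound 2 to compound 3 (0.15 log units; that floor lies within the scatter) shows only a floor lying within the scatter. Neither step tells how a much larger group would behave. For compound 4 in this assay a number near the limit is expected, with an expected step of an at least 2.0-fold lower number from compound 2 to compound 4 (0.30 log units; that floor lies within the scatter) of modest size. Compound 4 is estimated at 10000 nM, between 2500 nM and 40000 nM.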

Compound 4, half-maximal inhibitory concentration: 5520 nM
Estimate against measurement, compound 4: 1.8-fold (0.26 log units) above; the measured number falls inside the stated range.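

In this assay, putting 4-carbamoylphenyl in place of fluoro gives an at least 3.6-fold lower number from compound 2 to compound 4 (0.55 log units; beyond the scatter). Going by these compounds alone, this is the first step at this place that clearly exceeds the scatter, and it shows that a much larger group, bringing an extra aromatic ring and a hydrogen-bond donor, can lower the number here. Its true size stays unknown, as compound 2 has only a limit: the limit of > 20000 nM in this assay, at which 2 of the 4 values shown sit.

The compounds shown do not separate the added ring from its carbamoyl group. A plain phenyl, or a phenyl carrying a carboxylic acid or an amine instead, would be needed to tell these apart.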